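Benzyl ether variation on the shared core: cytotoxicity notes

The source may report more compounds than this note shows. Statements on the series, on what has been measured and on what is new or still open speak of the compounds shown alone.

Compound 1 `Cc1ccccc1COc1cc(O)c2c(=O)c(O)c(-c3ccccc3)oc2c1` gives in an ADME assay on Huh-5-2 cells (Homo sapiens) for cytotoxicity, read by WST assay, with a stated time of 3 days (a higher number here means that more compound is tolerated, a lower number that less compound is tolerated), a value of 17000 nM. For compound 2 `COc1ccccc1COc1cc(O)c2c(=O)c(O)c(-c3ccccc3)oc2c1` this assay reports only a limit, > 100000 nM. For compound 3 `O=c1c(O)c(-c2ccccc2)oc2cc(OCc3cccc(Cl)c3)cc(O)c12` this assay likewise reports only a limit, > 100000 nM. The steps of an at least 5.8-fold higher number from compound 1 to compound 2 (0.76 log units; beyond the scatter) and an at least 5.8-fold higher number from compound 1 to compound 3 (0.76 log units; beyond the scatter) both run up to that limit, and the step that the two limits leave unreadable from compound 2 to compound 3 cannot be read because of the limit of > 100000 nM in this assay, at which 2 of the 3 values shown sit. Compound 3 thus stands at the limit, where two of the three values sit, with compound 1 the only one resolved below it.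

Compound 4 `O=c1c(O)c(-c2ccccc2)oc2cc(OCc3cccc([N+](=O)[O-])c3)cc(O)c12` differs from compound 3 by nitro in place of chloro on an aromatic carbon. Among the compounds with values here, no measured step exchanges one group on the benzyl ring for another of this kind; the step from compound 1 to compound 3 changes the whole benzyl substituent and the step from compound 1 to compound 2 a methyl for a methoxy, and both end at the limit. Starting from a limit, the number for compound 4 can only be read if it falls below it. Compound 4 is expected to give about 70000 nM in this assay, within 20000 nM to 200000 nM. This estimate means an expected step of an at least 1.4-fold lower number from compound 3 to compound 4 (0.15 log units; that floor lies within the scatter), which may well stay unreadable.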

Compound 4, half-maximal cytotoxic concentration: 76000 nM
The estimate for compound 4 lay 1.1-fold (0.04 log units) below the measured number, and the stated range covers the measured number.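

With nitro in place of chloro on an aromatic carbon, the series gains a second resolved number in this assay: compound 4 gives 76000 nM. The exchange itself reads only as a floor, an at least 1.3-fold lower number from compound 3 to compound 4 (0.11 log units; that floor lies within the scatter), and the same holds for an at least 1.3-fold lower number from compound 2 to compound 4 (0.11 log units; that floor lies within the scatter), because both steps start from a limit of the assay: the limit of > 100000 nM in this assay, at which 2 of the 4 values shown sit.
Within the data shown here, the one step between two resolved numbers is a 4.5-fold higher number from compound 1 to compound 4 (0.65 log units; beyond the scatter), which leaves compound 1 as the least tolerated of the four, since its steps to all the others are printed as beyond the scatter.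

As far as these compounds go, how far the true numbers of compound 2 and compound 3 lie past the limit stays open, and with it whether chloro and nitro differ at all at this place on the ring. Also open, from the compounds shown here alone, is how an amine or a carboxylic acid in place of the nitro group would read in this assay, and whether either would fall as low as compound 1.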